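The compounds below may be only part of what the source reports. "The series", "measured", "known", "first", "only" and "open" are said of these compounds alone.

In a functional assay on MV4-11 cells (Homo sapiens) for antiproliferative activity, read by CCK-8 assay, with a stated time of 72 h (on this read-out higher numbers stand for weaker inhibition and lower numbers for stronger inhibition), compound 1 (`Cn1cc(-c2ccccc2Oc2ccccc2)c2cc(C(=O)NCCCCCC(=O)NO)[nH]c2c1=O`) gives 610 nM. Compound 3 (`Cn1cc(-c2ccccc2Oc2ccccc2)c2cc(C(=O)NCc3ccc(C(=O)NO)cc3)[nH]c2c1=O`) gives 570 nM, level with compound 1 within the scatter. Compound 2 (`Cn1cc(-c2ccccc2F)c2cc(C(=O)NCc3ccc(C(=O)Nc4ccccc4N)cc3)[nH]c2c1=O`) gives 230 nM, a lower number than compound 1 and beyond the scatter.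

Compound 4 (`Cn1cc(-c2ccccc2Oc2ccccc2)c2cc(C(=O)NCCCCCCC(=O)Nc3ccccc3N)[nH]c2c1=O`) is still unmeasured. The change is ((2-aminophenyl)carbamoyl)methyl in place of hydroxycarbamoyl on a saturated chain carbon, five bonds along the chain from an amide-type nitrogen.

Within the data shown here, the only measured single-place step, a 1.1-fold lower number from compound 1 to compound 3 (0.03 log units; within the scatter), stays within the scatter. It keeps the hydroxycarbamoyl group, so it says nothing direct about replacing that group. Among the measured compounds shown here, no measured step makes this replacement. For the measured compounds named here, compound 2 at 230 nM is the only measured compound carrying the 2-aminophenyl amide, but it also differs from compound 1 elsewhere, so it offers only a weak hint that this group is tolerated in this assay.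

With so little direct evidence, no shift beyond the scatter is expected, and the estimated step is a 1.1-fold higher number from compound 1 to compound 4 (0.06 log units; within the scatter). For compound 4 the estimated value is 700 nM, with an expected range of 200 nM to 2500 nM.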

Compound 4, half-maximal inhibitory concentration: 130 nM
Beside the measured number, compound 4's estimate is 5.4-fold (0.73 log units) above it; measured number outside the range, below it.
By their numbers in this assay, from the lowest: compounds 4 and 2 (each within the scatter of the next); then compounds 3 and 1 (each within the scatter of the next).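

Working notes: in this assay, the hydroxycarbamoyl group at this place on the chain of compound 1 can be replaced without loss, and ((2-aminophenyl)carbamoyl)methyl gives a step beyond the scatter (a 4.7-fold lower number from compound 1 to compound 4 (0.67 log units; beyond the scatter)), while the earlier step (a 1.1-fold lower number from compound 1 to compound 3 (0.03 log units; within the scatter)) kept hydroxycarbamoyl and stayed within the scatter. The entering group has 11 heavy atoms against 4 for the leaving group and adds one six-membered aromatic ring of carbon only, with hydrogen-bond donors and acceptors equal in count, so a much larger end group is accepted at this place in this read-out. Nothing measured here accounts for the step, and the reason for it remains unknown.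

The change alters both the end group and the chain, as the same difference also reads (hydroxycarbamoyl)methyl to 2-((2-aminophenyl)carbamoyl)ethyl, so the compounds shown do not separate the contribution of the 2-aminophenyl amide from that of the extra chain carbon; a shorter chain carrying the same amide would address this. As far as these compounds go, how a carboxylic acid or a primary amine at this chain end would read in this assay also remains open.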